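The source may hold more compounds than are shown below. What is called first, only, known or untested is meant among the compounds shown, and "the series" means these compounds.

Compound 1 `N#CC1=C(N)Oc2c(N)cc3nc4ccccc4nc3c2C12C(=O)N(Cc1cnnn1-c1ccccc1Cl)c1ccccc12` gives 34400 nM in a functional assay on MCF7 cells (Homo sapiens) for antiproliferative activity, read by MTT assay, with a stated time of 48 h; on this read-out lower numbers stand for stronger inhibition and higher numbers for weaker inhibition.
Compound 2 `Cc1ccc(-n2nncc2CN2C(=O)C3(C(C#N)=C(N)Oc4c(N)cc5nc6ccccc6nc5c43)c3ccccc32)cc1Cl` gives in this assay only a limit of the assay, > 50000 nM.
Compound 3 `Cc1ccc(Cl)cc1-n1nncc1CN1C(=O)C2(C(C#N)=C(N)Oc3c(N)cc4nc5ccccc5nc4c32)c2ccccc21` gives 43500 nM in this assay.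

Among the two numbers that are not limits, compound 3 holds the higher one, yet the step of a 1.3-fold higher number from compound 1 to compound 3 (0.10 log units; within the scatter) stays within the usual scatter, and the step of an at least 1.1-fold lower number from compound 2 to compound 3 (0.06 log units; that floor lies within the scatter) rests on a limit whose floor also lies within the scatter. So compound 3 cannot be set apart from compound 1, and only loosely from compound 2, for which the limit of > 50000 nM in this assay, at which 1 of the 3 values shown sits, applies.

Compound 4 `N#CC1=C(N)Oc2c(N)cc3nc4ccccc4nc3c2C12C(=O)N(Cc1cnnn1-c1ccc(F)c(Cl)c1)c1ccccc12` differs from compound 3 in one place: 3-chloro-4-fluorophenyl in place of 5-chloro-2-methylphenyl on an aromatic nitrogen. All three measured steps concern the same kind of exchange, an aryl group on that aromatic nitrogen, and each of them stays within the scatter: an at least 1.4-fold higher number from compound 1 to compound 2 (0.16 log units; that floor lies within the scatter), a 1.3-fold higher number from compound 1 to compound 3 (0.10 log units; within the scatter) and an at least 1.1-fold lower number from compound 2 to compound 3 (0.06 log units; that floor lies within the scatter). On that basis no step beyond the scatter is expected in this assay for compound 4, in either direction.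

Compound 4 is therefore estimated at 40000 nM in this assay, between 20000 nM and 80000 nM. The expected step of a 1.1-fold lower number from compound 3 to compound 4 (0.04 log units; within the scatter) is one of no real change.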

Compound 4, half-maximal inhibitory concentration: 17800 nM
For compound 4 the middle estimate is 2.2-fold (0.35 log units) above the measured one; the whole stated range lies above it.
By their numbers in this assay, from the lowest: compounds 4, 1 and 3 (each within the scatter of the next, the first and the last beyond it). At a limit, above all of these: compound 2.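

In this assay the aryl group on the aromatic nitrogen of the five-membered ring now gives a step beyond the scatter, which none of the earlier exchanges at this position did: with 3-chloro-4-fluorophenyl in place of 5-chloro-2-methylphenyl, the result is a 2.4-fold lower number from compound 3 to compound 4 (0.39 log units; beyond the scatter) in the numbers. Fluoro in place of methyl on an aromatic carbon also gives a step beyond the scatter, an at least 2.8-fold lower number from compound 2 to compound 4 (0.44 log units; beyond the scatter) being the reading, but this figure is only a floor, as compound 2 stands at a limit of the assay: the limit of > 50000 nM in this assay, at which 1 of the 4 values shown sits.
The position therefore responds to the choice of aryl group, though not to every exchange, since the step from the 2-chlorophenyl group, a 1.9-fold lower number from compound 1 to compound 4 (0.29 log units; within the scatter) as printed, stays within the scatter, and compound 1 cannot be set apart from compound 4.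

The compounds shown leave open how much of the change belongs to the fluoro group and how much to the loss of the methyl group. They also leave open how this assay would respond to an unsubstituted phenyl, a methoxy group or an amine on that ring.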